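The source may hold more compounds than are shown below. What is called first, only, known or untested is meant among the compounds shown, and "the series" means these compounds.

Measured compounds:
compound 1, `c1cnc(-c2ccccc2OCC2=NCCN2)nc1` — in a functional assay for activation of Alpha-1B adrenergic receptor (Homo sapiens), read by calcium flux (a higher number here means that more compound is needed for the effect, a lower number that less compound is needed), compound 1 gives < 100000 nM, which is a limit of the assay and not a number.
compound 2, `c1ccc(-c2ccsc2)c(OCC2=NCCN2)c1` — in this assay compound 2 gives 15.9 nM.

Going by the values given here, compound 2 holds the only number in this assay; the one other value is a limit. The step from compound 1 to compound 2 is a step that the limit leaves unreadable from compound 1 to compound 2, and the limit of < 100000 nM in this assay, at which 1 of the 2 values shown sits, leaves its size unreadable.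

Compound 3 is `c1ccc(-c2ncc[nH]2)c(OCC2=NCCN2)c1`. It differs from compound 2 by 1H-imidazol-2-yl in place of thiophen-3-yl on an aromatic carbon. Among the compounds with values here, the only measured step that bears on it is the one from compound 1 to compound 2, which also exchanges one aromatic five- or six-membered ring on the same aromatic carbon and is unreadable in size because of the limit of < 100000 nM in this assay, at which 1 of the 2 values shown sits; so no reliable size can be transferred. Since that step replaced a nitrogen-containing ring with thiophen-3-yl, and compound 3 again carries a nitrogen-containing ring, compound 3 is expected to need more compound than compound 2, by a 31-fold higher number from compound 2 to compound 3 (1.50 log units; beyond the scatter), with wide uncertainty. Compound 3 is estimated at 500 nM, within 30 nM to 10000 nM.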

Compound 3, half-maximal effective concentration: < 100000 nM
Compound 3: a limit, no number; the forecaster's own chance of this, stated with the estimate: 15%; the middle value does not contradict the limit.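

In this assay compound 3 gives < 100000 nM, a limit and not a number. No step among compound 1, compound 2 and compound 3 can be read in size: the limit of < 100000 nM in this assay, at which 2 of the 3 values shown sit.

The compounds shown leave open how far compound 1 and compound 3 lie from compound 2 or from each other, with compound 2 alone holding a number.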